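Working notes on the amine substituent change from compound 3

The compounds below may be only part of what the source reports. "The series", "measured", "known", "first", "only" and "open" are said of these compounds alone.

Measured so far in an assay on VSM-A10 cells for antagonist activity at Endothelin-1 receptor (Rattus norvegicus); on this read-out higher numbers stand for weaker inhibition and lower numbers for stronger inhibition:
- compound 1 `Cc1noc(N(CC(=O)O)S(=O)(=O)c2ccc(N)cc2)c1C`: > 32000 nM, which is a limit of this assay and not a number.
- compound 2 `CN(C)c1cccc2c(S(=O)(=O)Nc3onc4c3CCCC4)cccc12`: 153000 nM.
- compound 3 `Cc1noc(NS(=O)(=O)c2cccc3c(NCc4ccccc4)cccc23)c1C`: 590 nM.

Compound 3 has the lowest of the two numbers recorded in this assay. The nearest of them belongs to compound 2, whose number lies well beyond the scatter above that of compound 3. Compound 1 sits at the limit of > 32000 nM in this assay, at which 1 of the 3 values shown sits, and gives no number to compare. Among the compounds with values here, no two of the measured compounds differ in a single place, so no measured step is available.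

Compound 4 `CCOC(=O)C(C)Nc1cccc2c(S(=O)(=O)Nc3onc(C)c3C)cccc12` is not yet measured. It differs from compound 3 in one place: 1-(ethoxycarbonyl)ethyl in place of benzyl on a nitrogen on an aromatic ring. The new group keeps the same heavy-atom count but trades the ring for a chain carrying two acceptors.

Within the data shown here, with no measured step to lean on, the expectation for compound 4 in this assay is a modest weakening relative to compound 3, of a size around a 2.5-fold higher number from compound 3 to compound 4 (0.41 log units; beyond the scatter), with the possibility that it falls within the scatter. Compound 4 is estimated at 1500 nM, with a likely range from 300 nM to 8000 nM.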

Compound 4, half-maximal inhibitory concentration: 400 nM
For compound 4 the middle estimate is 3.8-fold (0.57 log units) above the measured one; the measured number falls inside the stated range.
By their numbers in this assay, from the lowest: compounds 4 and 3 (each within the scatter of the next); then compound 2.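

In this assay, within the data shown here, 1-(ethoxycarbonyl)ethyl in place of benzyl on a nitrogen on an aromatic ring gives a 1.5-fold lower number from compound 3 to compound 4 (0.17 log units; within the scatter), the first step that can be read in one place. At this position, then, an open chain with no ring and with hydrogen-bond acceptors, of the same heavy-atom count as benzyl, reads the same as the aromatic group within the scatter, so for this pair the six-membered aromatic ring is not required to keep the number at this level. Nothing at hand bears on why the two groups read alike.

As far as these compounds go, it remains open whether this holds for a free carboxylic acid in place of the ethyl ester, for a plain alkyl chain without the ester, or for an unsubstituted amine at the same nitrogen. The step is also read on a single shared core, so whether the two groups would read alike on any other core is an open question.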